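The source may report more compounds than this note shows. Statements on the series, on what has been measured and on what is new or still open speak of the compounds shown alone.

Working notes on the series. In a functional assay on HT-29 cells (Homo sapiens) for inhibition, read by sulforhodamine B assay, with a stated time of 48 h (a lower number here means a stronger inhibitor of growth, a higher number a weaker inhibitor of growth), compound 1 (`c1ccc(-c2ccc(NC3=NCCO3)cc2)cc1`) gives 5800 nM as its reading, while compound 2 (`c1cc(OC2CCCCCC2)ccc1NC1=NCCO1`) gives 16600 nM as its reading. Compound 1 therefore holds the lower of the two numbers and is the stronger growth inhibitor of this pair, with a gap beyond the usual scatter. Among the measured compounds shown here, the two compounds differ in more than one place, so no single-change step is available as a guide. Still unmeasured is compound 3 (`Ic1ccc(NC2=NCCO2)cc1`), which carries iodo in place of phenyl on an aromatic carbon, para to a group of 6 heavy atoms (iodo in place of phenyl on an aromatic carbon). For the measured compounds named here, the basis for an expectation is thin: compound 1, at 5800 nM in this assay, carries the phenyl that leaves, and no measured compound shows whether iodo keeps that level. The expected change is a 2.4-fold higher number from compound 1 to compound 3 (0.38 log units; beyond the scatter) as a move towards weaker growth inhibition, probably beyond the scatter, though a smaller step remains possible. For compound 3 the estimated value is 14000 nM with an expected range of 5000 nM to 40000 nM in this assay.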

Compound 3, concentration for 50% growth inhibition: 1300 nM
For compound 3 the middle estimate is 11-fold (1.03 log units) above the measured one; the whole stated range lies above it.
By their numbers in this assay, from the lowest: compound 3; then compound 1; then compound 2.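

Among the compounds shown here, the step from phenyl to iodo gives the only single-change reading in this assay, a 4.5-fold lower number from compound 1 to compound 3 (0.65 log units; beyond the scatter), and it shows that the phenyl on this aromatic carbon, para to a group of 6 heavy atoms, is not required for growth inhibition. In this pair, a single iodine atom in place of 6 carbon atoms and their aromatic ring gives the stronger growth inhibitor, so at this position, the larger group does not give the lower number. No accompanying measurement explains this step.

The compounds shown leave open whether this gain is particular to iodo or would also appear with a smaller halogen such as bromo or chloro, or with a non-halogen group such as methyl, methoxy, an amine or a carboxylic acid at the same place. They also leave open how a substituted phenyl or a longer chain would read at this position, and whether the iodo-for-phenyl step would hold in a second growth assay on another cell line.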